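A few compounds are considered here, and "the series" means these few. Any claim that something is new, unique, unknown or untested is made for them only; others in the source may bear on it.

Compound 1 `Cc1ccc(C(C)C)c(OCCSC(=S)N[C@H]2CCOC2=O)c1`: in a functional assay on DU-145 cells (Homo sapiens) for antiproliferative activity, read by MTT assay, with a stated time of 72 h (a higher number here means a weaker inhibitor, a lower number a stronger inhibitor), compound 1 gives > 64000 nM, a limit of the assay and not a number.
Compound 2 `CC(C)c1ccc(NCC(=O)N[C@H]2CCOC2=O)cc1`: in this assay compound 2 gives > 64000 nM, again only a limit.

Compound 2 therefore stands at the limit of > 64000 nM in this assay, at which 2 of the 2 values shown sit, so no number locates it. Compound 3 `O=C(CNc1ccccc1)N[C@H]1CCOC1=O` differs from compound 2 by hydrogen in place of isopropyl on an aromatic carbon. No measured step of this kind is shown, so nothing among these compounds points to a gain beyond the scatter. Compound 3 is expected to stay at the limit, with an estimated step that the limit leaves unreadable from compound 2 to compound 3. The estimate for compound 3 in this assay is 80000 nM, between 30000 nM and 250000 nM.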

Compound 3, half-maximal inhibitory concentration: > 64000 nM
Compound 3 gave a limit, no number; the forecaster's own chance of this, stated with the estimate: 85%; the middle value lies beyond the limit too.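

Compound 2 and compound 3 both give only a limit of the assay, so no step can be read between them, and all the compounds shown sit at that limit: the limit of > 64000 nM in this assay, at which 3 of the 3 values shown sit.
As far as these compounds go, whether the isopropyl group matters, and whether any close relative reaches a readable value in this assay, stays open.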